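The source may report more compounds than this note shows. Statements on the series, on what has been measured and on what is new or still open speak of the compounds shown alone.

Three compounds have been measured in a functional assay on MCF7 cells (Homo sapiens) for antiproliferative activity, read by sulforhodamine B assay, with a stated time of 72 h, tested at 10 uM; a lower number here means a stronger effect, a higher number a weaker effect of the compound at the concentration tested:
compound 1, `COc1cc(Br)cc(/C=C/C(=O)c2ccc(C)cc2)c1O`, gives 96.8%;
compound 2, `COc1cc(Br)cc(/C=C/C(=O)c2ccc(Br)cc2)c1O`, gives 64.6%;
compound 3, `N#CC1=C(N)Oc2ccc(Br)cc2C1CC(=O)c1ccc(Br)cc1`, gives 47.2%.

Compound 1 and compound 2 share one core and differ in a single spot: methyl in place of bromo on an aromatic carbon. In this assay this change made a step of a number 32.2 percentage points higher from compound 2 to compound 1 (beyond the scatter), that is, toward a weaker effect. Compound 3 stands on a different core, and how that core differs from the core of compound 2 is not broken down here. Compound 4, `Cc1ccc(C(=O)CC2C(C#N)=C(N)Oc3ccc(Br)cc32)cc1`, has not been measured; it arises from compound 3 by the same change, (methyl in place of bromo on an aromatic carbon), at the same place. Within the data shown here, only one example of this change has been measured, and it sits on another core, so the expectation rests on a single step. For compound 4 the expected step is a number 22.8 percentage points higher from compound 3 to compound 4 (beyond the scatter), because the earlier step came to a number 32.2 percentage points higher from compound 2 to compound 1 (beyond the scatter), though a different core may carry the same change differently. Compound 4 is therefore estimated at 70% in this assay, with a likely range from 48% to 92%.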

Compound 4, a percentage reported as activity, at one concentration (the size of the read-out at that concentration, not a potency): 69%
Compound 4: the middle estimate sits 1 percentage points above what was measured; the measured number falls inside the stated range.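

In this assay, replacing 4-bromophenyl with 4-methylphenyl gave a step of a number 21.8 percentage points higher from compound 3 to compound 4 (beyond the scatter), again toward a weaker effect, so the change pointed the same way on both cores. Set side by side, the two steps cannot be told apart in size: the same change on two cores in this assay, a number 32.2 percentage points higher (beyond the scatter) from compound 2 to compound 1 and a number 21.8 percentage points higher (beyond the scatter) from compound 3 to compound 4, 10.4 percentage points apart, within the scatter of two such steps. For these two pairs, then, the change carried over from one core to the other, but two pairs cannot show that it would do so on a third core, and they say nothing about why the effect weakens; each compound was also read at a single concentration, so this describes the size of the effect and not potency.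

The compounds shown leave open how an amine, a carboxylic acid or a longer chain such as butyl would behave in place of the bromo, as only bromo and methyl appear there. They also leave open what replacing the other bromo, which all four compounds keep, would do.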